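Shifting the hydroxyl on the aryl ring of a chromene

The source may hold more compounds than are shown below. What is called first, only, known or untested is meant among the compounds shown, and "the series" means these compounds.

Of the compounds shown here, two have been measured here. Compound 1 `CC1=C(c2ccc(O)cc2)C(c2ccc(OC[C@H](C)N3CC[C@@H](C)C3)cc2)Oc2cc(O)ccc21` gives 0.2 nM in a functional assay on MCF7 cells (Homo sapiens) for antiproliferative activity, read by CellTiter-Glo, with a stated time of 5 days (on this read-out lower numbers stand for stronger inhibition and higher numbers for weaker inhibition), the lowest of the two numbers. Compound 2 `CC1=C(c2cccc(F)c2)C(c2ccc(OC[C@H](C)N3CC[C@@H](C)C3)cc2)Oc2ccc(O)cc21` gives 1 nM in this assay, a higher number than compound 1 by a step that lies beyond the usual scatter; the two structures differ in more than one place, so their values are simply shown side by side without a single change to credit.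

Compound 3 `CC1=C(c2cccc(O)c2)C(c2ccc(OC[C@H](C)N3CC[C@@H](C)C3)cc2)Oc2cc(O)ccc21` has not been measured. It differs from compound 1 by one change, 3-hydroxyphenyl in place of 4-hydroxyphenyl on a double-bonded ring carbon: the same atoms are present, but the hydroxyl now sits at a different point of the ring that is attached to the double-bonded ring carbon of the shared core. Among the compounds with values here, no measured pair in this set isolates such a change, so the size of the step rests on judgement alone.

The expectation is a modest loss: the step from compound 1 to compound 3 in this assay is estimated at a 5.0-fold higher number from compound 1 to compound 3 (0.70 log units; beyond the scatter), a little beyond the scatter. Compound 3 is therefore expected to give about 1 nM in this assay, with a likely range from 0.3 nM to 4 nM.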

Compound 3, half-maximal inhibitory concentration: 0.3 nM
The estimate for compound 3 lay 3.3-fold (0.52 log units) above the measured number, and the stated range covers the measured number.
By their numbers in this assay, from the lowest: compounds 1 and 3 (each within the scatter of the next); then compound 2.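

In this assay the change from 4-hydroxyphenyl to 3-hydroxyphenyl on the double-bonded ring carbon gives a 1.5-fold higher number from compound 1 to compound 3 (0.18 log units; within the scatter) and so leaves the two compounds indistinguishable in this assay. Within the data shown here, this is the first pair here that differs in one place only, and it shows that, on the core of compound 1, the hydroxyl can sit at either of these two points on the ring without a step that rises above the scatter. No separate measurement is available to explain why the two placements read alike.

Still open is whether this ring needs a hydroxyl at all, since no compound shown isolates its removal or its replacement by a methoxy group, an amine or a carboxylic acid on the same core. The pair also tests only these two hydroxyl placements on this one ring and in this one cell assay, so it leaves open whether the same indifference would hold for other groups at these points.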